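This account rests on a few compounds, and the source may have more. Where it says the series, first, only, none or still open, it means among the compounds named here.

Compound 3, `O=C1N(CCCCCCOc2ccc(Br)cc2)CCN1c1cccnc1`, is the starting point of this step. In a functional assay on cells (Homo sapiens) for cytotoxicity (a lower number here means that less compound is tolerated, a higher number that more compound is tolerated), compound 3 gives > 25000 nM, which is a limit of the assay rather than a measured number. Its two companions are built on the same core and differ from compound 3 only in the group on the aromatic carbon. Compound 1, `O=C1N(CCCCCCOc2ccc(Cl)cc2)CCN1c1cccnc1`, gives > 25000 nM in this assay, again a limit. Compound 2, `O=C1N(CCCCCCOc2ccc(C(F)(F)F)cc2)CCN1c1cccnc1`, gives > 25000 nM, also a limit. Among the measured compounds shown here, every value so far therefore sits at the limit of > 25000 nM in this assay, at which 3 of the 3 values shown sit. The steps among these three, a step that the two limits leave unreadable from compound 1 to compound 2, a step that the two limits leave unreadable from compound 1 to compound 3 and a step that the two limits leave unreadable from compound 2 to compound 3, cannot be sized, and all three concern the group on the aromatic carbon, not the ring on the other end of the molecule.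

Compound 4, `O=C1N(CCCCCCOc2ccc(Br)cc2)CCN1c1ccncn1`, changes that other end: pyrimidin-4-yl in place of pyridin-3-yl on an amide-type nitrogen in a ring. For the measured compounds named here, no measured step touches this position, so the only guide is that nothing measured has moved off the limit. Compound 4 is therefore expected to stay at the limit, with an estimated half-maximal cytotoxic concentration of 30000 nM, between 12500 nM and 100000 nM. The expected step is a step that the limit leaves unreadable from compound 3 to compound 4, which is no change beyond the scatter.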

Compound 4, half-maximal cytotoxic concentration: > 25000 nM
Compound 4 gave a limit, no number; the forecaster's own chance of this, stated with the estimate: 80%; the middle value is on the limit's open side.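

In this assay compound 4 gives > 25000 nM which is again a limit and not a number, so the step from compound 3 to compound 4 cannot be read. The compounds shown leave open whether a change at either end of the molecule shifts this read-out at all, because every value rests at one limit: the limit of > 25000 nM in this assay, at which 4 of the 4 values shown sit.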